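The source may report more compounds than this note shows. Statements on the series, on what has been measured and on what is new or still open speak of the compounds shown alone.

Measured compounds:
Compound 1 `CN(C[C@H]1Cc2c(cccc2N2CCN(Cc3ccccn3)CC2)CN1)[C@H]1CCCc2cccnc21`: 4.2%
Compound 2 `CCCN(C[C@H]1Cc2c(cccc2N2CCNCC2)CN1)[C@H]1CCCc2cccnc21`: 100%
Compound 3 `CN(C[C@H]1Cc2c(cccc2N2CCN(C3CC3)CC2)CN1)[C@H]1CCCc2cccnc21`: 15.5%

These three compounds share one core and were tested in an ADME assay on microsomes from liver (Homo sapiens) for metabolic stability, read by LC-MS, with a stated time of 10 min; on this read-out higher numbers stand for a more stable compound and lower numbers for a less stable compound. Compound 3 stands second highest of the three: compound 1 sits below it, and compound 2 sits far above it. Among the measured compounds shown here, the only single-point step among them is a number 11.3 percentage points higher from compound 1 to compound 3 (beyond the scatter), a modest gain. Compound 2 is not linked to the others by a single change; its value and that of compound 3 simply show that compound 2 keeps much more of the compound.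

Compound 4 `C[C@@H]1CN(c2cccc3c2C[C@H](CN(C)[C@H]2CCCc4cccnc42)NC3)C[C@H](C)N1` is the untested member. It differs from compound 3 by 3,5-dimethylpiperazin-1-yl in place of 4-cyclopropylpiperazin-1-yl on an aromatic carbon. For the measured compounds named here, the one step that bears on changes at this ring is the modest gain from compound 1 to compound 3, so the data give little guide to how large the next step will be. The step of a number 24.5 percentage points higher from compound 3 to compound 4 (beyond the scatter) is the expected size, judged as uncertain. Compound 4 is estimated at 40%, with a range from 10% to 90%.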

Compound 4, percent of the compound remaining: 100%
Beside the measured number, compound 4's estimate is 60 percentage points below it, and the stated range ends below it.
By their numbers in this assay, from the lowest: compound 1; then compound 3; then compounds 2 and 4 (each within the scatter of the next).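

In this assay, among the compounds shown here, the group on this aromatic carbon turns out to matter far more than the earlier compounds showed: 3,5-dimethylpiperazin-1-yl in place of 4-cyclopropylpiperazin-1-yl gives a number 84.5 percentage points higher from compound 3 to compound 4 (beyond the scatter) and is a large step, whereas the earlier change on the ring nitrogen of the piperazine, a number 11.3 percentage points higher from compound 1 to compound 3 (beyond the scatter), was only modest. This new swap alters two things at once, since the cyclopropyl leaves that nitrogen and the dimethyl groups arrive on the ring, so the step cannot be assigned to either one alone. Nothing available explains why the number moves this much.

Still open, going by these compounds, is which part of the swap carries the step, which plain piperazin-1-yl on the same core would help to separate. On these data alone, how a morpholin-4-yl group would behave on this aromatic carbon also remains unknown.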